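Hydroxyalkylbenzyl variants: placing compound 3 against the series

A few compounds are considered here, and "the series" means these few. Any claim that something is new, unique, unknown or untested is made for them only; others in the source may bear on it.

Measured so far in an assay for inhibition of Amine oxidase [flavin-containing] B (Homo sapiens), read by fluorescence, using microsomes, with a stated time of 30 min; on this read-out lower numbers stand for stronger inhibition and higher numbers for weaker inhibition:
compound 1 `Cc1c(C)c2ccc(OCC3CCN(Cc4ccc(CO)cc4)CC3)cc2oc1=O` gives 29 nM
compound 2 `Cc1c(C)c2ccc(OCC3CCN(Cc4cccc(CO)c4)CC3)cc2oc1=O` gives 76 nM

Within the data shown here, compound 2 carries the higher of the two numbers; its only neighbour is compound 1, and the step of a 2.6-fold higher number from compound 1 to compound 2 (0.42 log units; beyond the scatter) is beyond the scatter, so compound 2 reads as the weaker of the pair in this assay.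

Compound 3 `Cc1c(C)c2ccc(OCC3CCN(Cc4ccc(CCO)cc4)CC3)cc2oc1=O` is not yet measured. Compared with compound 2, the change is 4-(2-hydroxyethyl)phenyl in place of 3-(hydroxymethyl)phenyl on a saturated chain carbon bound to an amine nitrogen in a ring.

Among the measured compounds shown here, the one measured step that bears on it is a 2.6-fold higher number from compound 1 to compound 2 (0.42 log units; beyond the scatter), which moved the hydroxymethyl group from the 4-position to the 3-position of the benzyl ring and raised the number modestly. For the measured compounds named here, compound 3 returns the substituent to the 4-position, which on that step alone points to a lower number, but the chain is also lengthened by one carbon, and no measured pair shows what such lengthening does. The step from compound 2 to compound 3 is therefore expected to be a 1.9-fold lower number from compound 2 to compound 3 (0.28 log units; within the scatter), downward, with wide uncertainty from the untested chain extension.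

Compound 3 is thus estimated at 40 nM, within 15 nM to 120 nM, in this assay.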

Compound 3, half-maximal inhibitory concentration: 120 nM
Beside the measured number, compound 3's estimate is 3.0-fold (0.48 log units) below it; the measured number falls inside the stated range.
By their numbers in this assay, from the lowest: compound 1; then compounds 2 and 3 (each within the scatter of the next).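

In this assay, among these compounds, going from 4-(hydroxymethyl)phenyl to 4-(2-hydroxyethyl)phenyl on a saturated chain carbon bound to an amine nitrogen in a ring gives a 4.1-fold higher number from compound 1 to compound 3 (0.62 log units; beyond the scatter) and is the first measured reading of chain length, a change beyond the scatter. The other new comparison, a 1.6-fold higher number from compound 2 to compound 3 (0.20 log units; within the scatter) in the same assay, gives no separation between 3-(hydroxymethyl)phenyl and 4-(2-hydroxyethyl)phenyl, so within these three compounds the 4-(hydroxymethyl)phenyl of compound 1 alone stands apart, as the strongest inhibitor, with steps to both others beyond the scatter. No evidence is available that accounts for these steps.

The compounds shown give only one chain extension, so they leave open whether a longer chain ending in hydroxy would continue the trend from compound 1 to compound 3 or whether that single step is all there is to it. They also leave open whether the hydroxy itself matters, which a plain ethyl group, an amine or a carboxylic acid in its place on the same benzyl ring would test.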